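From benzyl to 4-chlorophenyl on the amide-type nitrogen

The compounds below may be only part of what the source reports. "The series", "measured", "known", "first", "only" and "open" are said of these compounds alone.

Measured so far in a functional assay on HCT-116 cells (Homo sapiens) for antiproliferative activity, read by MTT assay, with a stated time of 72 h (on this read-out lower numbers stand for stronger inhibition and higher numbers for weaker inhibition), are two compounds:
- compound 1 `O=C(CCc1cccc2c1B(O)OC2)NC1CCCCC1` gives > 100000 nM (a limit)
- compound 2 `O=C(CCc1cccc2c1B(O)OC2)NCc1ccccc1` gives > 100000 nM (a limit)

Compound 2 thus has no number in this assay, only the limit > 100000 nM and nothing more. Both measured compounds share this position, as the record shows: the limit of > 100000 nM in this assay, at which 2 of the 2 values shown sit. Compound 3 `O=C(CCc1cccc2c1B(O)OC2)Nc1ccc(Cl)cc1` carries 4-chlorophenyl in place of benzyl on an amide-type nitrogen, and the count of the change reads (4-chlorophenyl in place of benzyl on an amide-type nitrogen). For the measured compounds named here, the only measured step bearing on this is a step that the two limits leave unreadable from compound 1 to compound 2, which offers no size to carry over. It concerns the same amide-type nitrogen, but no direction can be drawn from it, so no step beyond the scatter is expected. The expected step is a number no higher from compound 2 to compound 3 (the limit leaves the size open) as estimated here. For compound 3 the estimated value is 100000 nM in this assay, with an expected range from 40000 nM to 250000 nM.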

Compound 3, half-maximal inhibitory concentration: 12000 nM
The estimate for compound 3 lay 8.3-fold (0.92 log units) above the measured number; measured number below the stated range.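

The amide-type nitrogen turns out not to be a silent position: in this assay, 4-chlorophenyl gives an at least 8.3-fold lower number from compound 2 to compound 3 (0.92 log units; beyond the scatter), and against the cyclohexyl group it gives an at least 8.3-fold lower number from compound 1 to compound 3 (0.92 log units; beyond the scatter). Benzyl and 4-chlorophenyl match in heavy atoms and in hydrogen-bond donors and acceptors as counted, so these counts do not separate the active compound 3 from the compounds without a number. Compound 1 and compound 2 each remain at a limit of the assay rather than a number: the limit of > 100000 nM in this assay, at which 2 of the 3 values shown sit.

Going by these compounds, the full size of both steps stays open, and so does the share of the chlorine in them. A plain phenyl group on this nitrogen would separate the chlorine from the rest of the change, and a 4-methoxyphenyl group would show whether another substituent serves as well.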